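This account rests on a few compounds, and the source may have more. Where it says the series, first, only, none or still open, it means among the compounds named here.

Measured so far in an ADME assay on HOS cells (Homo sapiens) for cytotoxicity; a lower number here means that less compound is tolerated, a higher number that more compound is tolerated:
compound 1 `CN1CCC[C@@H](Cn2c(CN(C)[C@@H]3CCCc4cccnc43)nc3ccccc32)C1` – 2800 nM
compound 2 `CN1CCC(Cn2c(CN(C)C3CCCc4cccnc43)nc3ccccc32)C1` – 15000 nM
compound 3 `CN(Cc1nc2ccccc2n1C[C@H]1CCCN(Cc2cccnc2)C1)[C@H]1CCCc2cccnc21` – 2500 nM

Compound 3 (2500 nM) stands within the scatter of compound 1 (2800 nM), while compound 2 (15000 nM) has a higher number, beyond the scatter. The next step leads to compound 4 `CC(C)CCN1CCC[C@H](Cn2c(CN(C)[C@H]3CCCc4cccnc43)nc3ccccc32)C1` and reads isobutyl in place of pyridin-3-yl on a saturated chain carbon bound to an amine nitrogen in a ring. Compound 1 (2800 nM) carries neither group, yet its value is level with that of compound 3 (2500 nM) within the scatter. The expected change is a 1.1-fold lower number from compound 3 to compound 4 (0.06 log units; within the scatter) and is not expected to exceed the scatter in this assay at all. For compound 4 the estimated value is 2200 nM with an expected range of 800 nM to 6000 nM in this assay.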

Compound 4, half-maximal cytotoxic concentration: 2300 nM
Compound 4: middle estimate off by 1.0-fold (0.02 log units), on the low side; the range from low to high includes it.
By their numbers in this assay, from the lowest: compounds 4, 3 and 1 (each within the scatter of the next); then compound 2.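

In this assay, isobutyl in place of pyridin-3-yl on a saturated chain carbon bound to an amine nitrogen in a ring gives a 1.1-fold lower number from compound 3 to compound 4 (0.04 log units; within the scatter). This place in the series therefore accepts an open chain without a ring or hydrogen-bond acceptor in exchange for the aromatic ring, with no step beyond the scatter. No measured evidence bears on why the two compounds read alike.

Still open, as far as these compounds go, is whether a carboxylic acid or a primary amine at this place would also stay level with compound 4. The same question holds for a longer chain.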